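Trifluoromethyl for Methyl on the Core of Compound 1

A few compounds are considered here, and "the series" means these few. Any claim that something is new, unique, unknown or untested is made for them only; others in the source may bear on it.

Compound 1 `Cc1nc(Cl)ncc1C(=O)Nc1cc(C(F)(F)F)cc(C(F)(F)F)c1` stands lowest of three numbers in an assay on Jurkat cells for activation of nuclear factor NF-kappa-B complex (Homo sapiens) (a lower number here means a stronger inhibitor, a higher number a weaker inhibitor), where compound 1 gives 50 nM. Compound 2 `O=C(Nc1cc(C(F)(F)F)cc(C(F)(F)F)c1)c1cnc(Cl)cn1` gives 4000 nM and compound 3 `O=C(Nc1cc(C(F)(F)F)cc(C(F)(F)F)c1)c1ccc(Cl)nn1` gives 1700 nM, so both lie far from compound 1: an 80-fold higher number from compound 1 to compound 2 (1.90 log units; beyond the scatter) and a 34-fold higher number from compound 1 to compound 3 (1.53 log units; beyond the scatter). Between the two weaker compounds the gap is smaller, a 2.4-fold lower number from compound 2 to compound 3 (0.37 log units; beyond the scatter). Compound 4 `O=C(Nc1cc(C(F)(F)F)cc(C(F)(F)F)c1)c1cnc(Cl)nc1C(F)(F)F` differs from compound 1 by a single change: trifluoromethyl in place of methyl on an aromatic carbon. Within the data shown here, none of the measured steps bears directly on this change; each of them replaces the whole ring attached to the carbonyl carbon, and those replacements were large, while the methyl group was present only in compound 1. The data therefore give no measured guide for this substituent, and the step is expected to be modest, with a slight lean toward a higher number: a 2.4-fold higher number from compound 1 to compound 4 (0.38 log units; beyond the scatter). Compound 4 is estimated at 120 nM in this assay, with a range from 25 nM to 600 nM.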

Compound 4, half-maximal inhibitory concentration: 50 nM
Estimate against measurement, compound 4: 2.4-fold (0.38 log units) above; measured number inside the range.
By their numbers in this assay, from the lowest: compounds 1 and 4 (each within the scatter of the next); then compound 3; then compound 2.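

In this assay, trifluoromethyl in place of methyl on this aromatic carbon, next to the ring nitrogen, gives no change at the digits printed from compound 1 to compound 4 (within the scatter). The earlier compounds shown here replaced the whole ring attached to the carbonyl carbon, so they could not separate the methyl from the rest of that ring; this pair shows that the position accepts four heavy atoms where one stood, and that the low number of compound 1 does not depend on methyl in particular. Nothing shown explains why the two groups read alike. Going by these compounds, whether this carbon would hold its number with an amine, a carboxylic acid or a longer chain remains open. Also open, on these data alone, is whether a bare hydrogen at this position would do as well, which would show if any group there is needed at all.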